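Para-substituent series on the shared core: acid to alcohol

A few compounds are considered here, and "the series" means these few. Any claim that something is new, unique, unknown or untested is made for them only; others in the source may bear on it.

Measured compounds in a functional assay on PC-6 cells (Homo sapiens) for cytotoxicity, read by MTT assay, with a stated time of 3 days; a higher number here means a weaker inhibitor, a lower number a stronger inhibitor:
compound 1 `CN(C)Cc1ccc(/C=N/Nc2ncnc3sc(C(C)(C)C)cc23)cc1`, 0.107 ug/mL
compound 2 `CN(C)S(=O)(=O)c1ccc(/C=N/Nc2ncnc3sc(C(C)(C)C)cc23)cc1`, 2.12 ug/mL
compound 3 `CC(C)(C)c1cc2c(N/N=C/c3ccc(C(=O)O)cc3)ncnc2s1`, 7.22 ug/mL

Compound 3 gives the highest number of the three, with compound 2 nearest and compound 1 furthest away. The steps are a 20-fold higher number from compound 1 to compound 2 (1.30 log units; beyond the scatter), a 67-fold higher number from compound 1 to compound 3 (1.83 log units; beyond the scatter) and a 3.4-fold higher number from compound 2 to compound 3 (0.53 log units; beyond the scatter), so the group on the six-membered aromatic ring of carbon only, para to a large group, moves this assay strongly.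

Compound 4 `CC(C)(C)c1cc2c(N/N=C/c3ccc(CO)cc3)ncnc2s1` differs from compound 3 in one place: hydroxymethyl in place of carboxy on an aromatic carbon. The step of a 3.4-fold higher number from compound 2 to compound 3 (0.53 log units; beyond the scatter) bears most directly, since it shows a change away from carboxy lowering the number; the step of a 67-fold higher number from compound 1 to compound 3 (1.83 log units; beyond the scatter) shows how far such a change can reach. A modest step downward is therefore expected for compound 4, about a 3.6-fold lower number from compound 3 to compound 4 (0.56 log units; beyond the scatter), giving an estimated 2 ug/mL with a range of 0.5 ug/mL to 8 ug/mL.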

Compound 4, half-maximal inhibitory concentration: 0.556 ug/mL
For compound 4 the middle estimate is 3.6-fold (0.56 log units) above the measured one, and the stated range covers the measured number.
By their numbers in this assay, from the lowest: compound 1; then compound 4; then compound 2; then compound 3.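

In this assay, hydroxymethyl in place of carboxy gives a 13-fold lower number from compound 3 to compound 4 (1.11 log units; beyond the scatter), although the hydrogen-bond donor and acceptor counts of the two groups are the same, so this position responds strongly to a change those counts do not register. Hydroxymethyl also beats dimethylsulfamoyl, with a 3.8-fold lower number from compound 2 to compound 4 (0.58 log units; beyond the scatter), but falls short of (dimethylamino)methyl, with a 5.2-fold higher number from compound 1 to compound 4 (0.72 log units; beyond the scatter), which places it between them in this series. Nothing available explains these steps.

As far as these compounds go, whether the advantage of compound 1 needs its dimethylamino group remains open. An aminomethyl or methoxymethyl group at this place could show whether the result lies closer to compound 1 or to compound 4.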